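Swapping an amide on the pendant ring of a 15-PGDH inhibitor

The source may report more compounds than this note shows. Statements on the series, on what has been measured and on what is new or still open speak of the compounds shown alone.

Measured compounds:
- compound 1, `CCC[S+]([O-])c1sc2ncccc2c1N`: 151 nM
- compound 2, `CCCC[S+]([O-])c1sc2nc(-c3nccs3)cc(-c3ccc(CN)cc3)c2c1N`: 11.5 nM
- compound 3, `CCCC[S+]([O-])c1sc2nc(-c3nccs3)cc(-c3ccc(C(=O)N(C)C)cc3)c2c1N`: 5.9 nM

Of the compounds shown here, three have been tested in an assay for inhibition of 15-hydroxyprostaglandin dehydrogenase [NAD(+)] (Homo sapiens), read by fluorescence, with a stated time of 15 min, in the presence of a further agent that is not named here; a higher number here means a weaker inhibitor, a lower number a stronger inhibitor. Compound 1 carries the bare core and gives 151 nM. Compound 2 and compound 3 add two aromatic substituents to that core and are much stronger: compound 3 gives 5.9 nM, the lowest number of the three, while compound 2 sits within the scatter of it and compound 1 stands far higher.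

Compound 4, `CCCC[S+]([O-])c1sc2nc(-c3nccs3)cc(-c3ccc(CNC(C)=O)cc3)c2c1N`, is the next step. It differs from compound 3 in one place: acetamidomethyl in place of dimethylcarbamoyl on an aromatic carbon. For the measured compounds named here, the only step that bears on this position is a 1.9-fold lower number from compound 2 to compound 3 (0.29 log units; within the scatter), which shows that changing the group at this position between a basic amine and a tertiary amide moved the number very little. The acetamidomethyl group shares features with both, so no step beyond the scatter is expected for a 1.4-fold higher number from compound 3 to compound 4 (0.13 log units; within the scatter). Compound 4 is therefore estimated at 8 nM, with a range from 3 nM to 25 nM.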

Compound 4, half-maximal inhibitory concentration: 2.5 nM
Estimate against measurement, compound 4: 3.2-fold (0.51 log units) above, outside the stated range (below it).
By their numbers in this assay, from the lowest: compound 4; then compounds 3 and 2 (each within the scatter of the next); then compound 1.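

In this assay, this position proves able to separate groups beyond the scatter, which the step between compound 2 and compound 3 had not shown: the rearrangement of the same atoms gives a 2.4-fold lower number from compound 3 to compound 4 (0.37 log units; beyond the scatter). Placing acetyl on the amine nitrogen gives a 4.6-fold lower number from compound 2 to compound 4 (0.66 log units; beyond the scatter), so the aminomethyl group and its acetylated form can also be told apart, though only modestly. The entering acetamidomethyl group counts one hydrogen-bond donor where dimethylcarbamoyl counts none, but nothing measured here ties either step to that count or to any other feature of the groups.

The compounds shown leave open whether the amide hydrogen itself matters, a question that an acetamidomethyl group with a methyl on its nitrogen would address. They also leave open how a longer acyl chain, a sulfonamide or a carboxylic acid would fare at this position.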